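The source may hold more compounds than are shown below. What is called first, only, known or untested is meant among the compounds shown, and "the series" means these compounds.

Working notes on the series. For the measured compounds named here, compound 3 `Oc1ccc(-c2cc(-c3ccccn3)cc(-c3cccc(O)c3)n2)cc1` gives 980 nM in a functional assay on T47D cells (Homo sapiens) for cytotoxicity, read by CCK-8 assay (on this read-out lower numbers stand for stronger inhibition and higher numbers for weaker inhibition), and stands at the lowest of the three numbers so far. Compound 1 `Oc1ccc(-c2cc(-c3ccoc3)cc(-c3cccc(O)c3)n2)cc1` gives 2610 nM in this assay, and compound 2 `Oc1cccc(-c2cc(-c3ccccn3)cc(-c3ccccc3O)n2)c1` gives 2560 nM. The two steps that reach compound 3 are both modest and both beyond the scatter: a 2.7-fold lower number from compound 1 to compound 3 (0.43 log units; beyond the scatter) and a 2.6-fold lower number from compound 2 to compound 3 (0.42 log units; beyond the scatter).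

The next change keeps all atoms and rejoins them: pyridin-3-yl in place of pyridin-2-yl on an aromatic carbon, giving compound 4 `Oc1ccc(-c2cc(-c3cccnc3)cc(-c3cccc(O)c3)n2)cc1`. Going by the values given here, no measured step swaps one pyridinyl for another; the closest precedent is the furan-3-yl to pyridin-2-yl step from compound 1 to compound 3, which was only modest, and the hydroxyphenyl step from compound 2 to compound 3 was of the same size. Among the compounds with values here, with no direct precedent, the expectation for this assay is a step that is small, probably within the scatter, with no firm direction, so for compound 4 the expected step is a 1.5-fold higher number from compound 3 to compound 4 (0.18 log units; within the scatter). Compound 4 is estimated at 1500 nM, in the range 600 nM to 4000 nM.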

Compound 4, half-maximal inhibitory concentration: > 50000 nM
Compound 4: only a limit was reported (the forecaster's own chance of this, stated with the estimate: 5%); at least 33-fold (1.52 log units) between middle value and limit.
By their numbers in this assay, from the lowest: compound 3; then compounds 2 and 1 (each within the scatter of the next). At a limit, above all of these: compound 4.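

Rejoining the same atoms at the position opposite the ring nitrogen, with pyridin-3-yl in place of pyridin-2-yl, gives an at least 51-fold higher number from compound 3 to compound 4 (1.70 log units; beyond the scatter), a large step where the earlier steps were only modest. Carrying a pyridine at this position is therefore not enough for activity in this assay: the point of attachment on that ring matters, and pyridin-3-yl in place of furan-3-yl also gives an at least 19-fold higher number from compound 1 to compound 4 (1.28 log units; beyond the scatter). The reading for compound 4 is only a limit: the limit of > 50000 nM in this assay, at which 1 of the 4 values shown sits.

From the compounds shown here alone, what a pyridin-4-yl group or a plain phenyl group would give at this position stays open. Going by these compounds, it also stays open whether pyridin-3-yl would cost as much alongside the two hydroxyphenyl groups of compound 2.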